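The source may report more compounds than this note shows. Statements on the series, on what has been measured and on what is new or still open speak of the compounds shown alone.

Three compounds share one core and differ only in what hangs from it. Compound 1 `c1cc(-c2cn[nH]c2)c2c(c1)C(c1ncc[nH]1)CC2` carries a 1H-pyrazol-4-yl group, and in a functional assay on CHO cells for agonist activity at Alpha-1D adrenergic receptor (Homo sapiens), read by FLIPR and calcium flux (on this read-out lower numbers stand for an effect already at smaller amounts and higher numbers for an effect only at larger amounts of compound), compound 1 gives 319 nM. Among the compounds with values here, this is the only plain number among the three; the other two readings are limits of the assay. Compound 2 `Cc1ccc2c(c1NS(C)(=O)=O)CCC2c1ncc[nH]1` carries a methanesulfonamide group instead, and in this assay compound 2 gives only the limit > 10000 nM. Compound 3 `Cn1cc(-c2cccc3c2CCC3c2ncc[nH]2)cn1` has a methyl in place of hydrogen on an aromatic nitrogen of the pyrazole, and in this assay compound 3 likewise gives only the limit > 10000 nM. Within the data shown here, the single countable step is an at least 31-fold higher number from compound 1 to compound 3 (1.49 log units; beyond the scatter), a large loss whose size is set by the limit of > 10000 nM in this assay, at which 2 of the 3 values shown sit.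

Compound 4 `c1ccc2c(c1)CCC2c1ncc[nH]1` has not yet been measured. It differs from compound 1 by hydrogen in place of 1H-pyrazol-4-yl on an aromatic carbon. Among the measured compounds shown here, no measured pair removes the pyrazole outright, but both other measured variants of the core ended at the limit, so a large loss is the reasonable expectation here too. Compound 4 is therefore expected near 5000 nM, within a range of 1000 nM to 20000 nM, which means an expected step of a 16-fold higher number from compound 1 to compound 4 (1.20 log units; beyond the scatter).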

Compound 4, half-maximal effective concentration: > 10000 nM
Compound 4 gave a limit, no number (the forecaster's own chance of this, stated with the estimate: 50%); middle value at least 2.0-fold (0.30 log units) from the limit.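

Removing the 1H-pyrazol-4-yl group from this aromatic carbon altogether, rather than only placing a methyl on its nitrogen, gives in this assay an at least 31-fold higher number from compound 1 to compound 4 (1.49 log units; beyond the scatter). The core alone therefore does not reach a measurable effect in this assay, and compound 3 shows that the ring with a methyl on its nitrogen does not either, so among these compounds only compound 1, with the free 1H-pyrazol-4-yl group, gives a plain number, 319 nM. How compound 3 and compound 4 compare cannot be read, and the full size of the loss stays hidden because the readings stop at an assay limit: the limit of > 10000 nM in this assay, at which 3 of the 4 values shown sit.

Within the data shown here, still open is whether the pyrazole is the only group at this aromatic carbon that gives a measurable effect, or whether an amine, a carboxylic acid or a simple hydroxyl there would also give a plain number in this assay. Equally open, as far as these compounds go, is whether any group at this place could bring the number lower than that of compound 1.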